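Compound 3 to Compound 4: Swapping the Chain for an Aryl

The compounds below may be only part of what the source reports. "The series", "measured", "known", "first", "only" and "open" are said of these compounds alone.

Compound 1 `CCOC(=O)CN(Cc1ccccc1)c1nc(NCc2cccc(OC)c2)ncc1[N+](=O)[O-]` gives 57400 nM in a functional assay on MCF7 cells (Homo sapiens) for antiproliferative activity, read by MTT assay, with a stated time of 48 h; a lower number here means a stronger inhibitor, a higher number a weaker inhibitor. Compound 2 `CCOC(=O)CNc1nc(Nc2ccc(Cl)cc2)ncc1[N+](=O)[O-]` returns only the limit of the assay, > 100000 nM. Compound 3 `CCOC(=O)CNc1ncc([N+](=O)[O-])c(N(CC(=O)OCC)Cc2ccccc2)n1` likewise returns only the limit, > 100000 nM. On the numbers shown, compound 3 therefore stands at the weak end, with a single measured step leading to it, an at least 1.7-fold higher number from compound 1 to compound 3 (0.24 log units; that floor lies within the scatter), a change at a saturated chain carbon rather than at the ring nitrogen.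

Compound 4 `CCOC(=O)CN(Cc1ccccc1)c1nc(Nc2ccc(Cl)cc2)ncc1[N+](=O)[O-]` differs from compound 3 in one place: 4-chlorophenyl in place of (ethoxycarbonyl)methyl on a nitrogen on an aromatic ring. For the measured compounds named here, no measured step covers this exchange. Compound 2 already carries the (4-chlorophenyl)amino group and sits at the limit > 100000 nM. With the limit of > 100000 nM in this assay, at which 2 of the 3 values shown sit, describing most of the shown values, no step beyond the scatter is expected in this assay . Compound 4 is therefore estimated at 90000 nM, within 40000 nM to 250000 nM. The expected step is an at least 1.1-fold lower number from compound 3 to compound 4 (0.04 log units; that floor lies within the scatter), effectively no change.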

Compound 4, half-maximal inhibitory concentration: > 100000 nM
Compound 4 ended at the assay's limit; the forecaster's own chance of this, stated with the estimate: 55%; middle value at least 1.1-fold (0.04 log units) away from the limit.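

In this assay compound 4 gives > 100000 nM as a limit of the assay. The steps to compound 4 from compound 2 and compound 3 cannot be read, since both ends of each are limits, so neither the added benzyl nor the exchange of (ethoxycarbonyl)methyl for 4-chlorophenyl on this nitrogen has a measurable size. For the compounds shown here, the one readable step is an at least 1.7-fold higher number from compound 1 to compound 4 (0.24 log units; that floor lies within the scatter) and, with 4-chlorophenyl in place of 3-methoxybenzyl, it adds a further compound to those that give no number: the limit of > 100000 nM in this assay, at which 3 of the 4 values shown sit.

On these data alone, how far 4-chlorophenyl and (ethoxycarbonyl)methyl differ on this nitrogen remains open while both sit at a limit. Also open, as far as these compounds go, is whether a carboxylic acid in place of the ethoxycarbonyl, or an amine on the 4-chlorophenyl ring, would bring compound 4 to a readable number.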